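The compounds below may be only part of what the source reports. "The series", "measured", "known", "first", "only" and "open" are said of these compounds alone.

Measured compounds:
- compound 1, `c1ccc2c(c1)CC2CCCN1CCN(c2cccc3c2OCCO3)CC1`; in an assay for activation of Adrenergic receptor alpha-1 (Rattus norvegicus) (on this read-out lower numbers stand for an effect already at smaller amounts and higher numbers for an effect only at larger amounts of compound), compound 1 gives 0.45 mg/kg
- compound 2, `c1ccc2c(c1)CC2CCCCN1CCN(c2cccc3c2OCCO3)CC1`; in this assay compound 2 gives 7.15 mg/kg
- compound 3, `c1ccc2c(c1)CC2CN1CCN(c2cccc3c2OCCCO3)CC1`; in this assay compound 3 gives < 2.5 mg/kg

The value of compound 3 is a limit of the assay and not a number, as the limit of < 2.5 mg/kg in this assay, at which 1 of the 3 values shown sits, shows. Compound 2 differs from compound 1 by a group of 9 heavy atoms (9 carbon; one four-membered non-aromatic ring of carbon only, one six-membered aromatic ring of carbon only) in place of a group of 8 heavy atoms (8 carbon; one four-membered non-aromatic ring of carbon only, one six-membered aromatic ring of carbon only), on a saturated chain carbon, three bonds along the chain from an amine nitrogen in a ring, and that step gave a 16-fold higher number from compound 1 to compound 2 (1.20 log units; beyond the scatter). Compound 3 and compound 1 do not share the same core; the difference between the two cores is not broken down here.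

Compound 4, `c1ccc2c(c1)CC2CCN1CCN(c2cccc3c2OCCCO3)CC1`, is not yet measured. It differs from compound 3 by a group of 9 heavy atoms (9 carbon; one four-membered non-aromatic ring of carbon only, one six-membered aromatic ring of carbon only) in place of a group of 8 heavy atoms (8 carbon; one four-membered non-aromatic ring of carbon only, one six-membered aromatic ring of carbon only), on a saturated chain carbon bound to an amine nitrogen in a ring. Going by the values given here, this is the same kind of change as the one from compound 1 to compound 2, though the place differs: here it sits on a saturated chain carbon bound to an amine nitrogen in a ring, there three bonds along the chain from an amine nitrogen in a ring.

A step in the same direction is expected, an at least 2.0-fold higher number from compound 3 to compound 4 (0.30 log units; that floor lies within the scatter), resting on a 16-fold higher number from compound 1 to compound 2 (1.20 log units; beyond the scatter). Since the starting value of compound 3 is only a limit, the range must stay wide. Compound 4 is expected to give 5 mg/kg in this assay, between 1 mg/kg and 25 mg/kg.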

Compound 4, dose for half-maximal effect: 6.96 mg/kg
The estimate for compound 4 lay 1.4-fold (0.14 log units) below the measured number; the measured number falls inside the stated range.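

In this assay, the group of 9 heavy atoms in place of the group of 8 heavy atoms, on a saturated chain carbon bound to an amine nitrogen in a ring, gave an at least 2.7-fold higher number from compound 3 to compound 4 (0.44 log units; beyond the scatter). The change therefore points the same way on both cores, at two different places along the chain, but these two pairs support no rule beyond compounds 1 to 4, and whether its size carries over stays undecided: the same change on two cores in this assay, a 16-fold higher number (1.20 log units; beyond the scatter) from compound 1 to compound 2 and an at least 2.7-fold higher number (0.44 log units; beyond the scatter) from compound 3 to compound 4; the limit leaves it open whether they differ. Compound 3 stands as a limit of the assay and not a number: the limit of < 2.5 mg/kg in this assay, at which 1 of the 4 values shown sits.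

Still open is whether the same direction holds for a longer chain on the core of compound 3, where only the two chains of compound 3 and compound 4 are shown. Also open, on these data alone, is whether a chain carrying a hydroxyl group or an amide would follow the plain carbon chains seen on either core.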